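Changing the amine group of compound 2

This account rests on a few compounds, and the source may have more. Where it says the series, first, only, none or still open, it means among the compounds named here.

Compound 1 `CC(C)=CCc1cc(C(=O)Nc2cc3ccc(OCCCNCC(=O)O)c(C)c3oc2=O)ccc1O`: 18100 nM
Compound 2 `CC(C)=CCc1cc(C(=O)Nc2cc3ccc(OCCCNC(C)(C)c4ccccc4)c(C)c3oc2=O)ccc1O`: 1070 nM

In a functional assay on MCF7 cells (Homo sapiens) for antiproliferative activity (on this read-out higher numbers stand for weaker inhibition and lower numbers for stronger inhibition), compound 2 has the lower of the two numbers, 1070 nM. Compound 3 `CC(C)=CCc1cc(C(=O)Nc2cc3ccc(OCCCN(C)Cc4ccccc4)c(C)c3oc2=O)ccc1O`, not yet measured, differs from it as follows: benzyl(methyl)amino in place of (1-methyl-1-phenylethyl)amino on a saturated chain carbon, three bonds along the chain from an oxygen on an aromatic ring. Both groups hold one six-membered aromatic ring of carbon only. For the measured compounds named here, the sole measured step, a 17-fold lower number from compound 1 to compound 2 (1.23 log units; beyond the scatter), was large, and it replaced carboxymethyl with a group holding such a ring, which compound 3 keeps. One step is thin evidence, but no change beyond the scatter is expected. The estimated step is a 1.1-fold higher number from compound 2 to compound 3 (0.05 log units; within the scatter). For compound 3 the expected value is 1200 nM, with an estimated range of 450 nM to 3500 nM.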

Compound 3, half-maximal inhibitory concentration: 11500 nM
For compound 3 the middle estimate is 9.6-fold (0.98 log units) below the measured one; the measured number lies above the stated range.
By their numbers in this assay, from the lowest: compound 2; then compounds 3 and 1 (each within the scatter of the next).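

In this assay, keeping the aromatic ring does not keep the activity: an 11-fold higher number from compound 2 to compound 3 (1.03 log units; beyond the scatter), so at this position the ring alone does not set the number. With a 1.6-fold lower number from compound 1 to compound 3 (0.20 log units; within the scatter), a group holding that ring and carboxymethyl, which holds none, cannot be told apart here. Nothing measured here explains the difference.

This change alters two things at once: the nitrogen swaps its hydrogen for a methyl, and the carbon bearing the ring loses two methyl groups. Which of these matters remains open, and benzylamino, which keeps that hydrogen and lacks all these methyl groups, would help separate them.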